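The source may hold more compounds than are shown below. What is called first, only, known or untested is meant among the compounds shown, and "the series" means these compounds.

Measured so far in a functional assay on MDA-MB-231 cells (Homo sapiens) for inhibition, read by MTT assay, with a stated time of 48 h; a higher number here means a weaker inhibitor, a lower number a stronger inhibitor
Compound 1 `COc1ccc(-c2nc3ccccn3c2Sc2ccccc2)cc1` gives > 100000 nM, which is a limit.
Compound 2 `C(=C/c1nc2ccccn2c1Sc1ccccc1)\c1ccccc1` gives 25300 nM.

Going by the values given here, compound 2 holds the only actual number. Next is compound 3 `N#Cc1ccc(-c2nc3ccccn3c2Sc2ccccc2)cc1`, with 4-cyanophenyl in place of 2-phenylethenyl on an aromatic carbon. Among the compounds with values here, the only measured step bearing on this is an at least 3.9-fold lower number from compound 1 to compound 2 (0.59 log units; beyond the scatter), and it rests on (the limit of > 100000 nM in this assay, at which 1 of the 2 values shown sits). Like 4-methoxyphenyl, 4-cyanophenyl has no double bond outside aromatic rings, so much of an at least 3.9-fold lower number from compound 1 to compound 2 (0.59 log units; beyond the scatter) is expected to reverse. The expected change is a 2.0-fold higher number from compound 2 to compound 3 (0.30 log units; within the scatter), towards a weaker inhibitor. Compound 3 is estimated at 50000 nM, with an expected range of 15000 nM to 120000 nM.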

Compound 3, half-maximal inhibitory concentration: 17800 nM
Compound 3: middle estimate off by 2.8-fold (0.45 log units), on the high side; the measured number falls inside the stated range.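

The double bond outside aromatic rings is not needed at this aromatic carbon: the step shows a 1.4-fold lower number from compound 2 to compound 3 (0.15 log units; within the scatter). With the phenyl ring kept, the group on it matters, with cyano in place of methoxy giving an at least 5.6-fold lower number from compound 1 to compound 3 (0.74 log units; beyond the scatter). The size of that second step stays open-ended, as compound 1 gives a limit and not a number: the limit of > 100000 nM in this assay, at which 1 of the 3 values shown sits.

Still open, as far as these compounds go, is whether an amine, a carboxylic acid or a longer chain on that phenyl ring would give a stronger inhibitor. Also open, from the compounds shown here alone, is how much the phenylsulfanyl group contributes.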